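The compounds below may be only part of what the source reports. "The series", "measured", "known", "first", "only" and "open" are said of these compounds alone.

Among the compounds with values here, compound 1 `COC(=O)c1ccc(NCc2cncn2Cc2ccccc2Cl)cc1-c1ccccc1` was examined in a toxicity assay on NIH3T3 cells (Mus musculus) for cytotoxicity, read by resazurin assay (on this read-out lower numbers stand for an effect already at smaller amounts and higher numbers for an effect only at larger amounts of compound), where compound 1 gives 10000 nM, the only plain number among the three values at hand. Compound 2 `O=C(c1ccc(NCc2cncn2Cc2ccc(-c3ccccc3)cc2)cc1-c1ccccc1)N1CCCCC1` reaches only > 1000 nM in this assay, a limit of the assay rather than a number. Compound 3 `c1ccc(Cn2cncc2CNc2cccc(-c3cccnc3)c2)cc1` likewise shows > 1000 nM in this assay, again a limit. This matches (the limit of > 1000 nM in this assay, at which 2 of the 3 values shown sit). Compound 4 `COC(=O)c1ccc(NCc2cncn2Cc2ccccc2Br)cc1-c1ccccc1` has not been measured; it differs from compound 1 by bromo in place of chloro on an aromatic carbon. Within the data shown here, no step between measured compounds is available for this change, so its size can only be estimated, and the swap of one halogen for another at the same place is expected to move this assay little, if at all, within the scatter of repeated measurements. Compound 4 is therefore expected to give 10000 nM, between 4000 nM and 25000 nM, an expected step of no change at the digits printed from compound 1 to compound 4 (within the scatter).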

Compound 4, half-maximal effective concentration: 10000 nM
Beside the measured number, compound 4's estimate shows no gap at the digits printed, within the range that was stated.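

In this assay, within the data shown here, bromo in place of chloro on this aromatic carbon, ortho to a large group, gives the first step that can be read: no change at the digits printed from compound 1 to compound 4 (within the scatter). Before this, no pair differing in one place was available, so this position had no reading; now the 2-chlorobenzyl and 2-bromobenzyl forms stand level. On these data alone, whether a group of another kind here, such as an amine or a carboxylic acid, would move this assay stays open. The remaining values offer little further comparison: the limit of > 1000 nM in this assay, at which 2 of the 4 values shown sit.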